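Isoflavone ether series: carboxy to methyl at the branched carbon

This account rests on a few compounds, and the source may have more. Where it says the series, first, only, none or still open, it means among the compounds named here.

Three compounds of the shared core carry different ethers on the aromatic oxygen. Compound 1 `O=c1c(-c2ccc(O)cc2)coc2cc(OCCOCCOCCO)ccc12` gives 40 nM in an assay (Cricetulus griseus) for inhibition of aldehyde dehydrogenase, mitochondrial (Homo sapiens); a lower number here means a stronger inhibitor, a higher number a weaker inhibitor. Compound 2 `O=C(O)CCCCOc1ccc2c(=O)c(-c3ccc(O)cc3)coc2c1` gives 100 nM, and compound 3 `CC(Oc1ccc2c(=O)c(-c3ccc(O)cc3)coc2c1)C(=O)O` gives 2500 nM. Compound 3 stands at the highest number of the three: the step of a 63-fold higher number from compound 1 to compound 3 (1.80 log units; beyond the scatter) is large, and so is the step of a 25-fold higher number from compound 2 to compound 3 (1.40 log units; beyond the scatter); the step of a 2.5-fold higher number from compound 1 to compound 2 (0.40 log units; beyond the scatter) is modest by comparison.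

Compound 4 `CC(C)Oc1ccc2c(=O)c(-c3ccc(O)cc3)coc2c1` differs from compound 3 in one place: methyl in place of carboxy on a saturated chain carbon bound to an oxygen on an aromatic ring and a saturated chain carbon. Among the measured compounds shown here, no measured step removes a carboxy while keeping the rest of the ether unchanged, so none bears on this change directly. What the measured steps show is that the 1-carboxyethyl ether of compound 3 gives the weakest binding of the set, with the steps to compound 3 from compound 1 and from compound 2 both large. Taking the carboxy away from that branched carbon leaves a small isopropoxy ether; the expectation is that compound 4 moves back toward the numbers of compound 1 and compound 2 rather than further away, with a step of an 8.3-fold lower number from compound 3 to compound 4 (0.92 log units; beyond the scatter) expected in this assay. For the measured compounds named here, the estimate for compound 4 is therefore 300 nM, within a range of 60 nM to 1500 nM, with wide uncertainty because no measured step matches this change.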

Compound 4, half-maximal inhibitory concentration: 80 nM
Beside the measured number, compound 4's estimate is 3.8-fold (0.57 log units) above it, and the stated range covers the measured number.
By their numbers in this assay, from the lowest: compounds 1, 4 and 2 (each within the scatter of the next, the first and the last beyond it); then compound 3.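

Notes on the ether at the aromatic oxygen: in this assay, methyl in place of carboxy on the saturated chain carbon gives a 31-fold lower number from compound 3 to compound 4 (1.49 log units; beyond the scatter), so the high number of compound 3 goes with the carboxy on that carbon and not with a short branched ether as such. The small isopropoxy ether of compound 4 also reads level with the two long ethers, with a 1.3-fold lower number from compound 2 to compound 4 (0.10 log units; within the scatter) and a 2.0-fold higher number from compound 1 to compound 4 (0.30 log units; within the scatter), so within these compounds a long chain on this oxygen is not required for numbers in this range, and the carboxy of compound 2, carried at the end of the 4-carboxybutyl chain, does not bring the loss seen with the 1-carboxyethyl ether of compound 3. Nothing available explains why the carboxy on the branched carbon costs so much in this series.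

Open: a carboxymethyl ether would separate the carboxy from the branching methyl of compound 3. A methyl ester or a primary amide on the branched carbon would show whether the high number follows the carboxy alone or any carbonyl group at that place.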